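The source may hold more compounds than are shown below. What is called first, only, known or untested is meant among the compounds shown, and "the series" means these compounds.

Measured compounds:
compound 1, `CCCC1=C(OC)C(CCC)(CCC)C(=O)/C(=C(O)\C=C\c2ccccc2)C1=O` — 3.7 uM
compound 2, `COC1=C(CC(C)C)C(=O)/C(=C(O)/C=C/c2ccccc2)C(=O)C1(CC(C)C)CC(C)C` — 8 uM

In a functional assay on 1A9 cells (Homo sapiens) for antiproliferative activity, read by sulforhodamine B assay, with a stated time of 3 days (a lower number here means that less compound is needed, a higher number that more compound is needed for the effect), compound 1 gives the lowest of the two numbers; compound 2 gives a higher number, and that gap lies beyond the usual scatter. Compound 3, `CCCC1=C(OCC(C)C)C(CCC)(CCC)C(=O)/C(=C(O)\C=C\c2ccccc2)C1=O`, has not yet been measured. It differs from compound 1 in one place: isopropyl in place of hydrogen on a saturated chain carbon bound to an oxygen on an unsaturated carbon. Within the data shown here, with no measured pair showing this change, the expectation rests on the two measured values alone, and a small step in this assay is expected, if any, probably toward a slightly higher number. The estimated step of a 1.4-fold higher number from compound 1 to compound 3 (0.13 log units; within the scatter) gives an expected value for compound 3 of 5 uM, within a range from 1.5 uM to 15 uM.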

Compound 3, concentration for half-maximal effect: 6.9 uM
Compound 3: middle estimate off by 1.4-fold (0.14 log units), on the low side, within the range that was stated.
By their numbers in this assay, from the lowest: compounds 1, 3 and 2 (each within the scatter of the next, the first and the last beyond it).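

In this assay replacing methoxy with isobutoxy gives a 1.9-fold higher number from compound 1 to compound 3 (0.27 log units; within the scatter) so this position accepts the larger isobutyl chain on its oxygen without a change that stands out from the scatter. Compound 1 and compound 2 both carry methoxy here, so they could show nothing about this place. No available evidence explains the result.

Still open, from the compounds shown here alone, is whether this tolerance extends to a much longer chain, such as octyl, on the same oxygen. Going by these compounds, how a chain ending in an amine or a carboxylic acid would behave here also remains unknown.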